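This account rests on a few compounds, and the source may have more. Where it says the series, first, only, none or still open, it means among the compounds named here.

Compound 1 `COc1ccc(S(=O)(=O)NCCCN2CCN(c3cccc(OC)c3)CC2)cc1` is a sulfonamide whose aromatic ring on the far side of the molecule carries a methoxy group. In an assay on CHO cells for displacement of a labelled ligand from 5-hydroxytryptamine receptor 7 (Homo sapiens) (on this read-out higher numbers stand for weaker inhibition and lower numbers for stronger inhibition), compound 1 gives 339 nM. Compound 2 `COc1ccc(S(=O)(=O)NCCCN2CCN(c3ccccc3)CC2)cc1` is the same molecule with hydrogen in place of that methoxy on an aromatic carbon. In this assay compound 2 reaches only the limit of the measurement, > 10000 nM; that is not a number but the boundary beyond which the assay cannot read. The step is therefore an at least 29-fold higher number from compound 1 to compound 2 (1.46 log units; beyond the scatter), and compound 2 stands at the limit of > 10000 nM in this assay, at which 1 of the 2 values shown sits, the weakest position the measurement can report.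

Compound 3 `COc1ccc(S(=O)(=O)NC(C)CCN2CCN(c3ccccc3)CC2)cc1` keeps the bare aromatic ring of compound 2 and changes one spot on the linking chain: methyl in place of hydrogen on a saturated chain carbon bound to a saturated chain carbon and a sulfonamide nitrogen. Among the measured compounds shown here, no measured step touches this part of the molecule; the single measured step concerns the methoxy group elsewhere, so it gives no guidance on the size or direction of the present change. In this assay the expected step is therefore a step that the limit leaves unreadable from compound 2 to compound 3, none beyond the scatter. Compound 3 is expected to give about 15000 nM, within a range from 5000 nM to 50000 nM, and most likely once more only a limit rather than a number.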

Compound 3, half-maximal inhibitory concentration: 377 nM
Estimate against measurement, compound 3: 40-fold (1.60 log units) above; measured number below the stated range.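

Putting methyl in place of hydrogen on a saturated chain carbon bound to a saturated chain carbon and a sulfonamide nitrogen gives an at least 26-fold lower number from compound 2 to compound 3 (1.42 log units; beyond the scatter) in this assay. Among the compounds shown here, this is the first measured change on the linking chain, and it shows that one added carbon there can matter as much as the methoxy group on the far aromatic ring did. It also shows that a compound with the bare aromatic ring can still give a real reading in this assay, so losing the methoxy group does not by itself leave a compound at the limit. On these data alone, the full size of the step stays unknown because the value of compound 2 is a limit and not a number: the limit of > 10000 nM in this assay, at which 1 of the 3 values shown sits.

As far as these compounds go, it remains open whether ethyl, a longer chain or an amine on the same carbon would give a similar reading, or whether methyl on a different chain carbon would do the same. Also open is what happens when the chain methyl and the methoxy group on the far aromatic ring stand in one molecule, since the compounds shown never combine them.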